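Triazole aryl variation on the shared core: methoxy for trifluoromethyl

A few compounds are considered here, and "the series" means these few. Any claim that something is new, unique, unknown or untested is made for them only; others in the source may bear on it.

Measured so far in a functional assay on MCF7 cells (Homo sapiens) for cytotoxicity, read by MTT assay, with a stated time of 4 days; on this read-out lower numbers stand for stronger inhibition and higher numbers for weaker inhibition:
compound 1, `C=C1C(=O)[C@]23C[C@@]1(O)CC[C@H]2c1ccc(OS(=O)(=O)c2ccc(C)cc2)c(C)c1[C@@H]3Cn1cc(-c2ccc(Cl)cc2)nn1`, gives 1440 nM
compound 2, `C=C1C(=O)[C@]23C[C@@]1(O)CC[C@H]2c1ccc(O)c(C)c1[C@@H]3Cn1cc(-c2ccc(C(F)(F)F)cc2)nn1`, gives 1840 nM
compound 3, `C=C1C[C@]23C[C@@]1(O)CC[C@@H]2c1cccc(C)c1[C@@H]3Cn1cc(-c2ccccc2)nn1`, gives > 20000 nM, which is a limit of the assay and not a number.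

Of the two numbers on hand, compound 2 carries the higher one, but compound 1 sits within the scatter of it, so the two cannot be ordered. Within the data shown here, compound 3 gives only a limit, and no step to it can be stated.

Compound 4, `C=C1C(=O)[C@]23C[C@@]1(O)CC[C@H]2c1ccc(O)c(C)c1[C@@H]3Cn1cc(-c2ccc(OC)cc2)nn1`, is not yet measured. It differs from compound 2 as follows: methoxy in place of trifluoromethyl on an aromatic carbon. Read one bond further out, the change is 4-(trifluoromethyl)phenyl to 4-methoxyphenyl.

Among the measured compounds shown here, no measured step of this kind exists. For the measured compounds named here, the only comparison at the same position is compound 1 against compound 2, where a chloro and a trifluoromethyl land within the scatter of each other, so the position tolerates at least those two groups without a step beyond the scatter. On that basis the step from compound 2 to compound 4 is expected to be small, with no clear direction: the estimated step is a 1.1-fold higher number from compound 2 to compound 4 (0.04 log units; within the scatter). For compound 4 the expected value in this assay is 2000 nM, with a range from 900 nM to 5000 nM.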

Compound 4, half-maximal inhibitory concentration: 1710 nM
Compound 4: the middle estimate sits 1.2-fold (0.07 log units) above what was measured; low and high end bracket the measured number.
By their numbers in this assay, from the lowest: compounds 1, 4 and 2 (each within the scatter of the next). At a limit, above all of these: compound 3.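

In this assay, methoxy in place of trifluoromethyl on an aromatic carbon para to a large group gives a 1.1-fold lower number from compound 2 to compound 4 (0.03 log units; within the scatter), the only step of this kind in the compounds shown. Among these compounds, no earlier pair differed in one place, so this is the first reading at the position that isolates the group itself, and in this one pair a group with a hydrogen-bond acceptor replaces a group with none, with oxygen entering and fluorine leaving, and the number stays within the scatter. Nothing shown gives a cause for this flat response.

As far as these compounds go, whether the position stays this flat with an amine, a carboxylic acid or a longer chain on the same aromatic ring remains open, since one pair sets no pattern beyond compound 2 and compound 4. Compound 3 gives > 20000 nM, which is a limit of the assay and not a number, so steps to it cannot be read and the parts of the core in which it differs remain unresolved.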